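The compounds below may be only part of what the source reports. "The series", "measured", "known", "first", "only" and "open" are said of these compounds alone.

Compound 3 `COc1cc(NC(C)CCCNC(=O)Nc2cccc(O)c2)c2ncccc2c1` gives 27000 nM in a functional assay on SW-620 cells (Homo sapiens) for inhibition, read by MTT assay, with a stated time of 72 h; on this read-out lower numbers stand for stronger inhibition and higher numbers for weaker inhibition. Compound 1 `COc1cc(NC(C)CCCNC(=O)Nc2ccc(O)cc2)c2ncccc2c1` gives 30000 nM in this assay, and the step of a 1.1-fold lower number from compound 1 to compound 3 (0.05 log units; within the scatter) leaves the two side by side, so compound 3 holds the lower of the two numbers without standing apart from compound 1. Compound 2 `COc1cc(NC(C)CCCNC(=O)NNC(=O)Nc2ccc(O)cc2)c2ncccc2c1` reaches only a limit of this assay, > 100000 nM, and not a number. The steps of an at least 3.3-fold higher number from compound 1 to compound 2 (0.52 log units; beyond the scatter) and an at least 3.7-fold lower number from compound 2 to compound 3 (0.56 log units; beyond the scatter) therefore rest on that limit, (the limit of > 100000 nM in this assay, at which 1 of the 3 values shown sits).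

Compound 4 `COc1cc(NC(C)CCCNC(=O)Nc2ccc(Cl)cc2)c2ncccc2c1` has not been measured in this assay. It differs from compound 3 thus: 4-chlorophenyl in place of 3-hydroxyphenyl on an amide-type nitrogen. Among the compounds with values here, no measured step exchanges a hydroxyl for a chlorine on this phenyl; the closest is a 1.1-fold lower number from compound 1 to compound 3 (0.05 log units; within the scatter), which shows that swapping 4-hydroxyphenyl for 3-hydroxyphenyl changed nothing beyond the scatter, while the two steps through compound 2 concern an inserted carbamoylamino and bear little here. The step to compound 4 is expected to be small, a 1.1-fold lower number from compound 3 to compound 4 (0.03 log units; within the scatter), with no clear direction. Compound 4 is estimated at 25000 nM, between 8000 nM and 80000 nM.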

Compound 4, half-maximal inhibitory concentration: 28000 nM
The estimate for compound 4 lay 1.1-fold (0.05 log units) below the measured number, within the range that was stated.
By their numbers in this assay, from the lowest: compounds 3, 4 and 1 (each within the scatter of the next). At a limit, above all of these: compound 2.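

In this assay, 4-chlorophenyl in place of 3-hydroxyphenyl on the amide-type nitrogen gives a 1.0-fold higher number from compound 3 to compound 4 (0.02 log units; within the scatter), and chloro in place of hydroxy on the aromatic carbon gives a 1.1-fold lower number from compound 1 to compound 4 (0.03 log units; within the scatter). The earlier swap between the two hydroxyphenyl groups kept the hydroxyl, whereas here a group with 0 hydrogen-bond donors and 0 hydrogen-bond acceptors enters and both steps stay within the scatter. The one new step beyond the scatter is an at least 3.5-fold lower number from compound 2 to compound 4 (0.55 log units; beyond the scatter), and it rests on a limit, not on a number: the limit of > 100000 nM in this assay, at which 1 of the 4 values shown sits.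

On these data alone, it remains open whether another group on this phenyl, such as an amine or a carboxylic acid, would move the number beyond the scatter. As far as these compounds go, it is also open whether a longer chain between the core and the amide-type nitrogen would do so.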